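A few compounds are considered here, and "the series" means these few. Any claim that something is new, unique, unknown or untested is made for them only; others in the source may bear on it.

Among the compounds with values here, compound 2 `Cc1ccc(CNc2ccc(CCC(=O)O)cc2)cc1` stands highest of the two numbers so far in a functional assay on CHO cells for agonist activity at Free fatty acid receptor 1 (Homo sapiens), read by reporter gene assay (on this read-out higher numbers stand for larger maximal responses and lower numbers for smaller maximal responses), at 152%, with compound 1 `O=C(O)CCc1ccc(NCc2ccc(-c3ccccc3)cc2)cc1` next at 111%. Within the data shown here, the only measured step, a number 41 percentage points higher from compound 1 to compound 2 (beyond the scatter), was methyl in place of phenyl on an aromatic carbon and shows the position is sensitive. Compound 3 `O=C(O)CCc1ccc(NCc2ccc(C(=O)O)cc2)cc1` differs from compound 2 by carboxy in place of methyl on an aromatic carbon. Among the measured compounds shown here, no measured step involves carboxy here, so the direction is uncertain and a large step either way is possible. Compound 3 is expected at 70%, range 10% to 140%. The expected step is a number 82 percentage points lower from compound 2 to compound 3 (beyond the scatter).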

Compound 3, largest response reached (reported as percent of maximum), in percent of the reference or control that the assay uses: 9%
Compound 3: middle estimate off by 61 percentage points, on the high side, and the stated range ends above it.
By their numbers in this assay, from the lowest: compound 3; then compound 1; then compound 2.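

In this assay, the position tolerates both methyl and phenyl but not every group: the change to carboxy gives a number 143 percentage points lower from compound 2 to compound 3 (beyond the scatter) and, against the phenyl compound, a number 102 percentage points lower from compound 1 to compound 3 (beyond the scatter) in the same direction. Both steps exceed the one between the two earlier compounds, so the position's sensitivity extends to a loss of most of the response, not just a shift between high values. Nothing available accounts for this loss. Open, going by these compounds, is whether a methyl ester or a primary amide at this position would keep the response, and whether a hydroxymethyl group would behave more like methyl or carboxy.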